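Removing a tert-butoxycarbonyl group: expected tolerance of compound 4

A few compounds are considered here, and "the series" means these few. Any claim that something is new, unique, unknown or untested is made for them only; others in the source may bear on it.

Of the compounds shown here, three have been tested in an ADME assay on RAW264.7 cells (Mus musculus) for cytotoxicity, read by WST assay; a lower number here means that less compound is tolerated, a higher number that more compound is tolerated. Compound 1 `O=C(NCc1ccco1)c1ccc(Cn2c(=O)c3ccccc3[s+]2[O-])cc1` reaches only the limit of the assay, > 100000 nM. Compound 2 `CC(C)(C)OC(=O)c1ccc(CN2C(=O)c3ccccc3S2(=O)=O)cc1` likewise gives a limit, > 100000 nM. Compound 3 `CC(C)(C)OC(=O)N(C(=O)OC(C)(C)C)C(=O)c1ccc(CN2C(=O)c3ccccc3S2(=O)=O)cc1` also stops at a limit, > 100000 nM. Compound 3 therefore stands where every measured value stands, at the limit of > 100000 nM in this assay, at which 3 of the 3 values shown sit, and none of the three yields a number inside the measured range. Among the compounds with values here, no step between two measured compounds can be compared here.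

Compound 4 `CC(C)(C)OC(=O)NC(=O)c1ccc(CN2C(=O)c3ccccc3S2(=O)=O)cc1` differs from compound 3 by hydrogen in place of tert-butoxycarbonyl on an amide-type nitrogen. Because all three values sit at the limit of > 100000 nM in this assay, at which 3 of the 3 values shown sit, nothing in the data separates one structure from another, and no direction can be read from them. The expected step is a step that the limit leaves unreadable from compound 3 to compound 4, none beyond the scatter. Compound 4 is expected to tolerate a similarly high concentration, at an estimated 150000 nM within a range of 50000 nM to 500000 nM, with the assay most likely again reporting only its limit.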

Compound 4, concentration lethal to 50% of the cells: > 100000 nM
Compound 4: a limit, no number; the forecaster's own chance of this, stated with the estimate: 85%; the middle value does not contradict the limit.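

Compound 4 also stops at a limit, so the changes leading to it from compound 3 and from compound 2 cannot be read as steps: the limit of > 100000 nM in this assay, at which 4 of the 4 values shown sit.

The compounds shown leave open whether any change to these structures would give an actual number in this assay.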